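This account rests on a few compounds, and the source may have more. Where it says the series, first, only, none or still open, it means among the compounds named here.

Measured compounds in an ADME assay on CEM-SS cells (Homo sapiens) for cytotoxicity, read by XTT assay, with a stated time of 6 days; a higher number here means that more compound is tolerated, a lower number that less compound is tolerated: compound 1, `CCCC(=O)OCSc1ccccc1C(=O)NCCC(N)=O`; compound 2, `CCCC(=O)OCSc1ccccc1C(=O)NCCCCCCC(N)=O`, 10.4 uM; compound 3, `CCCC(=O)OCSc1ccccc1C(=O)OCC(N)=O`, 82.1 uM.

Compound 1 gives only a limit of this assay, > 100 uM. Among the two numbers compound 3 stands highest, higher than compound 2, a gap beyond the scatter.

Compound 4, `C#CCNC(=O)CNC(=O)c1ccccc1SCOC(=O)CCC`, is still to be measured. ((propargylcarbamoyl)methyl)amino in place of carbamoylmethoxy on a carbonyl carbon Two measured steps bear on it. Replacing the amide-type nitrogen linkage by an oxygen one, an at least 1.2-fold lower number from compound 1 to compound 3 (0.08 log units; that floor lies within the scatter), changed little. Lengthening the chain beyond the amide-type nitrogen, an at least 9.6-fold lower number from compound 1 to compound 2 (0.98 log units; beyond the scatter), lowered the number clearly. Compound 4 both restores the amide-type nitrogen and lengthens the chain, though less far than compound 2, so a modest lowering is expected, a 2.3-fold lower number from compound 3 to compound 4 (0.37 log units; beyond the scatter). The estimate for compound 4 is 35 uM, between 12 uM and 100 uM.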

Compound 4, half-maximal toxic concentration: 95.4 uM
Estimate against measurement, compound 4: 2.7-fold (0.44 log units) below, and the stated range covers the measured number.
By their numbers in this assay, from the lowest: compound 2; then compounds 3 and 4 (each within the scatter of the next). At a limit, above all of these: compound 1.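

On the carbonyl carbon, ((propargylcarbamoyl)methyl)amino in place of carbamoylmethoxy gives a 1.2-fold higher number from compound 3 to compound 4 (0.07 log units; within the scatter) in this assay, even though the group that enters holds 8 heavy atoms and a triple bond and the group that leaves holds 5. Propargylcarbamoyl in place of 5-carbamoylpentyl gives a 9.2-fold higher number from compound 2 to compound 4 (0.96 log units; beyond the scatter) and so shows that the low number of compound 2 does not come with every extension of the chain. Compound 1 carries only a limit: the limit of > 100 uM in this assay, at which 1 of the 4 values shown sits. Propargylcarbamoyl in place of carbamoylmethyl gives an at least 1.0-fold lower number from compound 1 to compound 4 (0.02 log units; that floor lies within the scatter), and this floor is all that can be read of the step.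

Going by these compounds, whether a longer chain ending in the propargyl amide keeps the number of compound 4 in this assay remains open. So does the outcome with an amine or a carboxylic acid at the chain end.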